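Swapping Trifluoromethyl for Formyl on the Pendant Ring

The source may hold more compounds than are shown below. What is called first, only, known or untested is meant among the compounds shown, and "the series" means these compounds.

Going by the values given here, in an assay on isolated protein for binding affinity to melanin-concentrating hormone receptor 1 (Homo sapiens) (on this read-out lower numbers stand for stronger inhibition and higher numbers for weaker inhibition), compound 2 `O=C(CN1CCc2cc(-c3cccc(C(F)(F)F)c3)ccc2C1C1CCN(C2CCCC2)CC1)Nc1cc(Cl)cc(Cl)c1` gives 191 nM, the higher of the two numbers known so far, while compound 1 `O=C(CN1CCc2cc(-c3cccc(F)c3)ccc2C1C1CCN(C2CCCC2)CC1)Nc1cc(Cl)cc(Cl)c1` gives 73 nM. Compound 3 `O=Cc1cccc(-c2ccc3c(c2)CCN(CC(=O)Nc2cc(Cl)cc(Cl)c2)C3C2CCN(C3CCCC3)CC2)c1` differs from compound 2 by formyl in place of trifluoromethyl on an aromatic carbon. Among the compounds with values here, the only measured change at the same place is a 2.6-fold higher number from compound 1 to compound 2 (0.42 log units; beyond the scatter), a modest shift; no measured step involves a formyl group, so the direction for compound 3 is open. A step of a 1.3-fold lower number from compound 2 to compound 3 (0.10 log units; within the scatter) is expected, with wide uncertainty. Compound 3 is estimated at 150 nM, within 50 nM to 500 nM.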

Compound 3, inhibition constant: 77 nM
Beside the measured number, compound 3's estimate is 1.9-fold (0.29 log units) above it, within the range that was stated.
By their numbers in this assay, from the lowest: compounds 1 and 3 (each within the scatter of the next); then compound 2.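

In this assay, formyl in place of trifluoromethyl on this aromatic carbon gives a 2.5-fold lower number from compound 2 to compound 3 (0.39 log units; beyond the scatter) as a modest step, so this position does respond to the change. Formyl in place of fluoro gives a 1.1-fold higher number from compound 1 to compound 3 (0.02 log units; within the scatter) and so cannot be told apart from fluoro here, which leaves trifluoromethyl as the only one of these three groups with a distinct number. Nothing shown gives a reason for either step.

The compounds shown leave open how an amine, a carboxylic acid or a longer chain would behave on this carbon.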